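Trimming a Cyclobutyl to Cyclopropyl on the Piperazine Ring

The source may report more compounds than this note shows. Statements on the series, on what has been measured and on what is new or still open speak of the compounds shown alone.

Of the compounds shown here, three have been measured in a functional assay on RMS13 cells for antagonist activity at Urotensin-2 receptor (Homo sapiens), read by FLIPR and calcium flux, with a stated time of 1 h; a higher number here means a weaker inhibitor, a lower number a stronger inhibitor. Compound 1 `CCN1CCN(c2cccc3c2C(=O)N([C@H](CCCNS(=O)(=O)c2cn(C)c(C)n2)c2ccc(OC)c(OC)c2)C3=O)CC1` gives 810 nM. Compound 2 `CCN1CCN(c2cccc3c2CN([C@H](CCCNS(=O)(=O)c2c[nH]cn2)c2ccc(OC)c(OC)c2)C3=O)CC1` gives 51 nM. Compound 3 `COc1ccc([C@@H](CCCN(C)S(=O)(=O)c2cccs2)N2Cc3c(cccc3N3CCN(C4CCC4)CC3)C2=O)cc1OC` gives 510 nM, the second highest of the three numbers; its value and that of compound 1 lie within the usual scatter of each other, while the value of compound 2 lies lower by a margin beyond that scatter. Compound 4 `COc1ccc([C@@H](CCCN(C)S(=O)(=O)c2cccs2)N2Cc3c(cccc3N3CCN(C4CC4)CC3)C2=O)cc1OC` differs from compound 3 by one change: cyclopropyl in place of cyclobutyl on an amine nitrogen in a ring. Among the measured compounds shown here, no measured pair shows this change, so a small step is expected from compound 3 to compound 4 in this assay, with a 1.2-fold higher number from compound 3 to compound 4 (0.07 log units; within the scatter) not beyond the scatter. Compound 4 is estimated at 600 nM, with a range from 250 nM to 1500 nM.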

Compound 4, half-maximal inhibitory concentration: 1200 nM
Compound 4: the middle estimate sits 2.0-fold (0.30 log units) below what was measured, and the stated range covers the measured number.
By their numbers in this assay, from the lowest: compound 2; then compounds 3, 1 and 4 (each within the scatter of the next, the first and the last beyond it).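

Trimming 4-cyclobutylpiperazin-1-yl to 4-cyclopropylpiperazin-1-yl removes a single carbon, yet it gives a 2.4-fold higher number from compound 3 to compound 4 (0.37 log units; beyond the scatter) in this assay. Among the compounds shown here, this is the first direct comparison at this amine nitrogen, and it shows that the group there matters: for this pair, cyclobutyl gives the stronger inhibitor. No measurement here explains the shift. On these data alone, whether cyclopentyl or isopropyl on the same nitrogen would give a lower or higher number remains open. A single pair also cannot show whether this step would hold with a different side chain on the shared core.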